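Swapping One Halogenated Ring on a Shared Core

The source may report more compounds than this note shows. Statements on the series, on what has been measured and on what is new or still open speak of the compounds shown alone.

Of the compounds shown here, three have been tested in an assay on isolated protein for inhibition of Alpha glucosidase (Homo sapiens), with stated times of 5 min and 15 min, tested at 50 uM; on this read-out higher numbers stand for more inhibition at the one concentration tested (going by the name of the read-out) and lower numbers for less inhibition. Compound 1 `COc1ccc(/C=C2\CCC/C(=C\c3ccccc3)C2=O)cc1` gives 31.4% in this assay, and compound 2 `O=C1/C(=C/c2ccccc2)CCC/C1=C\c1ccc(Br)cc1` gives 29.1%. Within the data shown here, the only step between two compounds that differ in a single place, bromo in place of methoxy on an aromatic carbon, is a number 2.3 percentage points lower from compound 1 to compound 2 (within the scatter). Compound 3 `O=C(/C=C(O)/C=C/c1cccc(O)c1)c1cc(Cl)ccc1O`, built on a different core, gives 62.4%.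

Compound 2 therefore stands lowest of the three numbers, with compound 1 nearest and within the scatter of it, and compound 3 furthest, beyond the scatter.

Compound 4 `O=C1/C(=C/c2ccccc2)CCC/C1=C\c1ccccc1Cl` has not been measured yet. It differs from compound 2 in one place: 2-chlorophenyl in place of 4-bromophenyl on a double-bonded chain carbon bound to a double-bonded ring carbon.

Among the measured compounds shown here, no measured step matches this exact change. For the measured compounds named here, the one step that resembles it, a change of substituent on the same aromatic ring, was a number 2.3 percentage points lower from compound 1 to compound 2 (within the scatter), within the scatter. On that basis a step of the same small kind is expected here: the step from compound 2 to compound 4 in this assay is estimated as a number 0.9 percentage points higher from compound 2 to compound 4 (within the scatter), with no clear direction beyond the scatter. Compound 4 is thus expected to give about 30% in this assay, plausibly between 18% and 42%.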

Compound 4, a percentage reported as inhibition, at one concentration (the size of the read-out at that concentration, not a potency): 43%
Beside the measured number, compound 4's estimate is 13 percentage points below it; the measured number lies above the stated range.
By their numbers in this assay, from the lowest: compounds 2 and 1 (each within the scatter of the next); then compound 4; then compound 3.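

In this assay, putting 2-chlorophenyl in place of 4-bromophenyl on a double-bonded chain carbon bound to a double-bonded ring carbon gives a number 13.9 percentage points higher from compound 2 to compound 4 (beyond the scatter), which shows that a change to this ring can move the read-out by more than the usual scatter, something the earlier change of methoxy to bromo did not show with its step of a number 2.3 percentage points lower from compound 1 to compound 2 (within the scatter). The two groups have the same count of heavy atoms and neither has a hydrogen-bond donor or acceptor, but the halogen and its place on the ring change together, so this single step cannot be credited to either alone. Nothing available here explains why the number rises.

The compounds shown leave open whether the halogen or its place on the ring matters more, a question that 4-chlorophenyl and 2-bromophenyl at this carbon could help separate. They also leave open how this ring would fare in this assay if it carried an amine or a carboxylic acid instead of a halogen.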